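Thiosemicarbazone series: aryl to pyrrolyl swap on the imine carbon

The source may hold more compounds than are shown below. What is called first, only, known or untested is meant among the compounds shown, and "the series" means these compounds.

Within the data shown here, compound 2, `CC1=CC[C@H](C(C)(C)NC(=S)N/N=C/c2ccc(Cl)cc2)CC1`, holds the lowest of the two numbers so far: in a functional assay on OVCAR-3 cells (Homo sapiens) for inhibition, read by sulforhodamine B assay, with a stated time of 48 h (a lower number here means a stronger inhibitor of growth, a higher number a weaker inhibitor of growth), compound 2 gives 26400 nM, while its nearest neighbour compound 1, `CC1=CC[C@H](C(C)(C)NC(=S)N/N=C/c2ccccc2Cl)CC1`, gives 83600 nM. Among the measured compounds shown here, the one measured step, a 3.2-fold lower number from compound 1 to compound 2 (0.50 log units; beyond the scatter), shows that moving the chlorine on the aryl group shifts the number beyond the scatter. Compound 3, `CC1=CC[C@H](C(C)(C)NC(=S)N/N=C/c2ccc[nH]2)CC1`, is not yet measured. It differs from compound 2 by 1H-pyrrol-2-yl in place of 4-chlorophenyl on a carbon with a double bond to nitrogen. For the measured compounds named here, no measured pair shows a phenyl ring giving way to a five-membered heteroaromatic ring, so the step from compound 1 to compound 2 bears only loosely: it shows this position is sensitive, but not the direction for a ring change. Loss of the chlorine and the six-membered ring is expected to weaken growth inhibition modestly, a step of a 1.7-fold higher number from compound 2 to compound 3 (0.23 log units; within the scatter). Compound 3 is therefore estimated at 45000 nM, within 14000 nM to 140000 nM.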

Compound 3, concentration for total growth inhibition: > 100000 nM
Compound 3: only a limit was reported; the forecaster's own chance of this, stated with the estimate: 10%; at least 2.2-fold (0.34 log units) between middle value and limit.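

In this assay compound 3 carries > 100000 nM, which is a limit and not a number: the limit of > 100000 nM in this assay, at which 1 of the 3 values shown sits. The exchange of 4-chlorophenyl for 1H-pyrrol-2-yl on a carbon with a double bond to nitrogen gives an at least 3.7-fold higher number from compound 2 to compound 3 (0.57 log units; beyond the scatter), so this position responds to a change of ring as well as to a shift of the chlorine, and here the change weakens growth inhibition. Set against 2-chlorophenyl, the same exchange gives an at least 1.1-fold higher number from compound 1 to compound 3 (0.07 log units; that floor lies within the scatter), so no order follows for that pair.

Whether the chlorine or the ring accounts for the step from 4-chlorophenyl remains open; an unsubstituted phenyl at this place would separate the two. A furan-2-yl would show whether the outcome holds for a five-membered aromatic ring without the ring hydrogen-bond donor.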